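A hydroxyethyl group added at the amine-bearing carbon

A few compounds are considered here, and "the series" means these few. Any claim that something is new, unique, unknown or untested is made for them only; others in the source may bear on it.

Compound 1 `CCCCCCCCc1ccc(CCC(N)(CO)C(=O)O)cc1`: > 10 mg/kg
Compound 2 `CCCCCCCCc1ccc(CCC(N)CO)cc1`: > 10 mg/kg
Compound 3 `CCCCCCCOc1ccc(CC[C@](N)(CO)CCC)cc1`: > 10 mg/kg

In a functional assay on the whole organism (spleen, spleen) with Rattus norvegicus as the target (a lower number here means that less compound is needed, a higher number that more compound is needed for the effect), compound 1 gives only a limit, > 10 mg/kg. Compound 2 likewise gives only a limit in this assay, > 10 mg/kg. Compound 3 also returns only a limit in this assay, > 10 mg/kg. Thus compound 2 stands at the same limit as every other measured compound; (the limit of > 10 mg/kg in this assay, at which 3 of the 3 values shown sit). Going by the values given here, the one step between two measured compounds that differ in one place, a step that the two limits leave unreadable from compound 1 to compound 2, is unreadable, since both ends are limits.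

Compound 4 `CCCCCCCCc1ccc(CCC(N)(CO)CCO)cc1` differs from compound 2 by 2-hydroxyethyl in place of hydrogen on a saturated chain carbon bound to an amine nitrogen and two saturated chain carbons. Among the compounds with values here, no measured step bears on this change, and the only measured step gives no size. With three limits and nothing else, the expected step of an at least 1.2-fold lower number from compound 2 to compound 4 (0.09 log units; that floor lies within the scatter) in this assay is set near no change, with a wide range. Compound 4 is therefore estimated at 8 mg/kg in this assay, between 1 mg/kg and 30 mg/kg, with a fair chance that the assay again reports only a limit.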

Compound 4, dose for 50% inhibition: 0.12 mg/kg
Compound 4: middle estimate off by 67-fold (1.82 log units), on the high side; measured number outside the range, below it.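

In this assay, the saturated chain carbon bound to an amine nitrogen and two saturated chain carbons now shows a readable effect, with 2-hydroxyethyl in place of hydrogen giving an at least 83-fold lower number from compound 2 to compound 4 (1.92 log units; beyond the scatter). The same group in place of carboxy on that carbon gives an at least 83-fold lower number from compound 1 to compound 4 (1.92 log units; beyond the scatter), so among these compounds, a change at this one carbon is enough to bring the result inside the range of the assay. Compound 4 is the only compound here that returns a number rather than a limit: the limit of > 10 mg/kg in this assay, at which 3 of the 4 values shown sit.

Going by these compounds, the size of both steps remains a minimum, and the true distance from compound 1 and compound 2 is unknown. The compounds shown also leave open whether an ethyl or a 3-hydroxypropyl group on this carbon would have the same effect.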